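The compounds below may be only part of what the source reports. "The series", "measured", "known", "first", "only" and "open" are said of these compounds alone.

Of the compounds shown here, three sharing one core have been measured in a functional assay on cells for antagonist activity at Free fatty acid receptor 1 (Homo sapiens), read by TR-FRET and inositol phosphate accumulation, with a stated time of 2 h; a higher number here means a weaker inhibitor, a lower number a stronger inhibitor. Compound 1 `Cc1cc(COc2cccc(Cl)c2)nc(-c2ccccn2)n1` gives 398 nM, compound 2 `COc1ccc(OCc2cc(C)nc(-c3ccccn3)n2)cc1` gives 7940 nM, and compound 3 `Cc1cc(COc2ccccc2C#N)nc(-c2ccccn2)n1` gives 10000 nM. Among these three numbers compound 2 stands second highest: its nearest neighbour is compound 3, whose number is within the usual scatter of its own, so no order between compound 2 and compound 3 can be read from these two values. Its furthest neighbour is compound 1, whose number lies far below, beyond the scatter, so compound 2 is the weaker inhibitor of that pair.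

Compound 4 `Cc1cc(COc2ccc(S(C)(=O)=O)cc2)nc(-c2ccccn2)n1` has not yet been measured. It differs from compound 2 in one place: methylsulfonyl in place of methoxy on an aromatic carbon, para to a large group. Among the measured compounds shown here, no measured pair shows this particular exchange, so nothing about its size can be taken from the measured compounds. For the measured compounds named here, the only guidance is that compound 2 and compound 3 both sit at the weak end of the three numbers. The step from compound 2 to compound 4 in this assay is therefore expected to be small, in either direction, or none beyond the scatter, as a 1.3-fold higher number from compound 2 to compound 4 (0.10 log units; within the scatter) expresses. On that basis compound 4 is estimated to give about 10000 nM in this assay, with a range from 3000 nM to 30000 nM.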

Compound 4, half-maximal inhibitory concentration: > 39800 nM
Compound 4: only a limit was reported; the forecaster's own chance of this, stated with the estimate: 40%; at least 3.9-fold (0.59 log units) between middle value and limit.
By their numbers in this assay, from the lowest: compound 1; then compounds 2 and 3 (each within the scatter of the next). At a limit, above all of these: compound 4.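

In this assay compound 4 gives > 39800 nM, which is a limit and not a number: the limit of > 39800 nM in this assay, at which 1 of the 4 values shown sits. Methylsulfonyl in place of methoxy on an aromatic carbon, para to a large group, is the first change in one place that can be read among these compounds, and it gives an at least 5.0-fold higher number from compound 2 to compound 4 (0.70 log units; beyond the scatter), which shows that the number responds to what stands at this position even though compound 2 already lay at the weak end. As far as these compounds go, only a lower bound of this step is available, so its true size stays unknown.

The compounds shown leave open whether the weakening is particular to methylsulfonyl or would follow from other replacements of methoxy at this position, such as an amine, a carboxylic acid or a longer alkoxy chain. From the compounds shown here alone, compound 1 and compound 3 are linked to compound 2 and compound 4 by no readable step, so what their chlorine and nitrile groups would do at this same position also remains open.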